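A few compounds are considered here, and "the series" means these few. Any claim that something is new, unique, unknown or untested is made for them only; others in the source may bear on it.

Of the compounds shown here, three have so far been measured in a functional assay on SW620/5-FU cells (Homo sapiens) for cytotoxicity, read by MTT assay, with a stated time of 48 h, in the presence of a further agent that is not named here; a lower number here means that less compound is needed, a higher number that more compound is needed for the effect. Compound 1 `Cn1ncc2c(-c3ccccc3)cc(NNC(=O)Nc3cc(Cl)nc(Cl)c3)nc21` gives 76900 nM, compound 2 `CCCc1cc(NNC(=O)Nc2cc(Cl)nc(Cl)c2)nc2c1cnn2C` gives 38700 nM, and compound 3 `Cn1ncc2c(-c3ccc(F)cc3)cc(NNC(=O)Nc3cc(F)cc(F)c3)nc21` gives 47400 nM. Within the data shown here, the only pair that differs in one place shows a 2.0-fold lower number from compound 1 to compound 2 (0.30 log units; within the scatter). Compound 3 has the second highest of the three numbers, and its gaps to compound 2 and to compound 1 are both within the scatter, so the three compounds cannot be told apart on these numbers.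

Compound 4 `Cn1ncc2c(-c3ccc(F)cc3)cc(NNC(=O)Nc3cc(Cl)nc(Cl)c3)nc21` is not yet measured. It differs from compound 3 in one place: 2,6-dichloropyridin-4-yl in place of 3,5-difluorophenyl on an amide-type nitrogen. Among the measured compounds shown here, the 2,6-dichloropyridin-4-yl group already sits on the amide-type nitrogen of compound 1 and compound 2, but no measured step exchanges it against 3,5-difluorophenyl, and the one step seen, a 2.0-fold lower number from compound 1 to compound 2 (0.30 log units; within the scatter), concerns another place; nothing measured bears directly on this change. Since compound 1 carries this group and gives 76900 nM, and all values lie in one band, compound 4 is expected to stay near it, with a 1.3-fold higher number from compound 3 to compound 4 (0.10 log units; within the scatter). Compound 4 is estimated at 60000 nM, between 25000 nM and 150000 nM.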

Compound 4, half-maximal effective concentration: 9150 nM
Beside the measured number, compound 4's estimate is 6.6-fold (0.82 log units) above it; the measured number lies below the stated range.
By their numbers in this assay, from the lowest: compound 4; then compounds 2, 3 and 1 (each within the scatter of the next).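

In this assay, 2,6-dichloropyridin-4-yl in place of 3,5-difluorophenyl on the amide-type nitrogen gives a 5.2-fold lower number from compound 3 to compound 4 (0.71 log units; beyond the scatter), which shows that this position can change the number beyond the scatter while the 4-fluorophenyl group stays in place. With 2,6-dichloropyridin-4-yl held fixed, 4-fluorophenyl in place of propyl gives a 4.2-fold lower number from compound 2 to compound 4 (0.63 log units; beyond the scatter), and fluoro in place of hydrogen on the aromatic carbon gives an 8.4-fold lower number from compound 1 to compound 4 (0.92 log units; beyond the scatter), so the other substituent also matters, at least in compound 4. Nothing measured here explains these steps.

The step at the amide-type nitrogen changes the ring nitrogen and the halogen together, so a dichlorophenyl group would be needed to separate them. Going by these compounds, whether chloro or methoxy could replace the fluoro of compound 4 also remains open.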